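This account rests on a few compounds, and the source may have more. Where it says the series, first, only, none or still open, it means among the compounds named here.

Measured in an in vitro ADME assay on microsomes (Rattus norvegicus) for metabolic stability; on this read-out lower numbers stand for a shorter-lived compound and higher numbers for a longer-lived compound
- Compound 1 `CCc1nc(-c2ccc(Cl)cc2Cl)c(CC)nc1NC(COC)COC` gives 0.0417 h
- Compound 2 `CCc1nc(-c2ccc(Cl)cc2Cl)c(CC)nc1NC(C1CC1)C1CC1` gives 0.0417 h
- Compound 3 `CCc1nc(-c2ccc(Cl)cc2Cl)c(CC)nc1NC(C)CN(C)C` gives < 0.0167 h (a limit of the assay)

Compound 3 is known only as a limit, < 0.0167 h, so its exact position in this assay is open. The side chains of the other two compounds show no separation, no change at the digits printed from compound 1 to compound 2 (within the scatter). The 1-((dimethylamino)methyl)ethyl group comes with a clear drop, an at least 2.4-fold lower number from compound 1 to compound 3 (0.39 log units; beyond the scatter) and an at least 2.4-fold lower number from compound 2 to compound 3 (0.39 log units; beyond the scatter), and both sizes are set by that limit.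

Compound 4 `CCCN(CCN(C)C)c1nc(CC)c(-c2ccc(Cl)cc2Cl)nc1CC` carries (2-(dimethylamino)ethyl)(propyl)amino in place of (1-((dimethylamino)methyl)ethyl)amino on an aromatic carbon. For the measured compounds named here, no measured step isolates this change. Like compound 3, compound 4 has a dimethylamino group, so the closest guide is an at least 2.4-fold lower number from compound 2 to compound 3 (0.39 log units; beyond the scatter), and the number is expected to stay at the bottom of the range, possibly again as a limit. Going by the values given here, the expected change is a number no lower from compound 3 to compound 4 (the limit leaves the size open), with no step expected beyond the scatter. For compound 4 the estimate is 0.0167 h, with an expected range of 0.008 h to 0.04 h.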

Compound 4, half-life: < 0.0167 h
Compound 4: only a limit was reported (the forecaster's own chance of this, stated with the estimate: 65%); the middle value lies on the limit itself.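

In this assay compound 4 gives < 0.0167 h, which is a limit of the assay and not a number. Its side chain shows an at least 2.4-fold lower number from compound 2 to compound 4 (0.39 log units; beyond the scatter) and an at least 2.4-fold lower number from compound 1 to compound 4 (0.39 log units; beyond the scatter), so the low reading at this position also appears with a dimethylamino side chain that has a propyl group on the attached nitrogen and no hydrogen-bond donor, unlike the side chain of compound 3. The step between compound 3 and compound 4 cannot be read, as both readings sit at the same limit: the limit of < 0.0167 h in this assay, at which 2 of the 4 values shown sit.

Any real difference between these two compounds under that limit stays open. From the compounds shown here alone, it is also open whether the dimethylamino group itself goes with the drop, which a morpholine or a primary amine at the end of the chain would test.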